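The compounds below may be only part of what the source reports. "The series", "measured", "known", "first", "only" and "open" are said of these compounds alone.

Working notes on the series in a functional assay on Mino cells (Homo sapiens) for cytotoxicity, read by MTT assay, with a stated time of 72 h; a higher number here means a weaker inhibitor, a lower number a stronger inhibitor.

Compound 1 `O=C1N=C(N2N=C(c3ccc(Br)cc3)CC2c2ccc(Cl)cc2)S/C1=C1\C(=O)Nc2ccc(Cl)cc21` gives 7400 nM and stands lowest of the three measured numbers. Compound 2 `O=C1N=C(Nc2ccc(O)cc2)S/C1=C\c1ccc(Cl)cc1` gives 61200 nM, and compound 3 `O=C1N=C(N2N=C(c3ccc(Cl)cc3)CC2c2ccc(Cl)cc2)S/C1=C1\C(=O)Nc2ccc(Cl)cc21` gives 80700 nM; both lie beyond the scatter from compound 1. For the measured compounds named here, the one single-point step among the measured compounds, an 11-fold higher number from compound 1 to compound 3 (1.04 log units; beyond the scatter), shows that a halogen swap at another aromatic carbon of the shared core moved this assay by a large amount.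

Compound 4 `O=C1N=C(N2N=C(c3ccc(Br)cc3)CC2c2ccc(Cl)cc2)S/C1=C1\C(=O)Nc2ccccc21` differs from compound 1 by hydrogen in place of chloro on an aromatic carbon. Going by the values given here, no measured pair changes this particular aromatic carbon, so no step bears directly on it. The only related observation is that a small halogen change elsewhere in the core produced the large step from compound 1 to compound 3, which argues against assuming the number will stay put. Removal of the chloro is expected to raise the number moderately, a 2.2-fold higher number from compound 1 to compound 4 (0.33 log units; beyond the scatter), with wide uncertainty. Compound 4 is therefore estimated at 16000 nM, with a range from 5000 nM to 60000 nM.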

Compound 4, half-maximal inhibitory concentration: 10000 nM
Compound 4: the middle estimate sits 1.6-fold (0.20 log units) above what was measured; the measured number falls inside the stated range.
By their numbers in this assay, from the lowest: compounds 1 and 4 (each within the scatter of the next); then compounds 2 and 3 (each within the scatter of the next).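

Removing the chloro from this aromatic carbon gives a 1.4-fold higher number from compound 1 to compound 4 (0.13 log units; within the scatter) in this assay, so hydrogen and chloro cannot be told apart here, at least with the bromo of compound 1 in place. The halogen at this place therefore makes no readable difference to the number, whereas the swap at the other halogen-bearing aromatic carbon gives an 11-fold higher number from compound 1 to compound 3 (1.04 log units; beyond the scatter) and so the two places do not behave alike in these compounds. Nothing available accounts for either outcome.

Still open, as far as these compounds go, is whether a larger or differently built group at this carbon, such as methoxy, an amine or a carboxylic acid, would also leave the number within the scatter. From the compounds shown here alone, it is also open whether hydrogen and chloro remain equivalent here when chloro replaces the bromo, as it does in compound 3.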